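The source may hold more compounds than are shown below. What is called first, only, known or untested is meant among the compounds shown, and "the series" means these compounds.

Measured so far:
Compound 1, `N=C(N)N/N=C/c1c(-c2ccsc2)nc2sccn12`, gives 29500 nM in a functional assay on cells (Cancer cell lines, Homo sapiens) for inhibition; on this read-out higher numbers stand for weaker inhibition of growth and lower numbers for stronger inhibition of growth.
Compound 2, `Cc1cc(-c2nc3sc(C)cn3c2/C=N/NC(=N)N)c(C)s1`, gives 32400 nM in this assay.

Compound 2 holds the higher of the two numbers, but its gap to compound 1 lies within the scatter, so the two read as equivalent on this assay. Among the compounds with values here, no pair of measured compounds differs in a single place, so nothing is yet known about how one isolated change moves this read-out.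

Compound 3, `Cc1cc(-c2nc3sccn3c2/C=N/NC(=N)N)c(C)s1`, is the next to be measured. Against compound 2 the change is hydrogen in place of methyl on an aromatic carbon. Within the data shown here, with only two compounds measured and no step isolating this kind of change, no shift beyond the scatter is expected in this assay; the expected step is a 1.1-fold lower number from compound 2 to compound 3 (0.03 log units; within the scatter). Compound 3 is estimated at 30000 nM, with a range from 12000 nM to 75000 nM.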

Compound 3, concentration for total growth inhibition: 32400 nM
Compound 3: the middle estimate sits 1.1-fold (0.03 log units) below what was measured; measured number inside the range.
By their numbers in this assay, from the lowest: compounds 1, 2 and 3 (each within the scatter of the next).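

Within the data shown here, the first single-place step at this position, hydrogen in place of methyl on an aromatic carbon next to the ring sulfur, gives in this assay no change at the digits printed from compound 2 to compound 3 (within the scatter), so this methyl is not needed to hold the read-out at this level. The second step, 2,5-dimethylthiophen-3-yl in place of thiophen-3-yl on an aromatic carbon, gives a 1.1-fold higher number from compound 1 to compound 3 (0.04 log units; within the scatter), so this exchange also leaves the read-out within the scatter. No supporting data accompany either step, and the result stands as a plain observation.

Only methyl and hydrogen are shown at this position, so it remains open whether an amine, a carboxylic acid or a longer alkyl chain on the same carbon would move the read-out beyond the scatter. Also open, as far as these compounds go, is whether a phenyl ring in place of the thiophen-3-yl group would do so.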